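A Sulfonamide in Place of a Nitrile

The compounds below may be only part of what the source reports. "The series", "measured", "known", "first", "only" and "open" are said of these compounds alone.

Compound 1 `N#Cc1ccc2[nH]c(Cc3ccc(Oc4ccccc4)cc3)nc2c1` gives 3400 nM in an assay on membranes from brain for binding affinity to Adrenergic receptor alpha-1 (Rattus norvegicus); a higher number here means a weaker inhibitor, a lower number a stronger inhibitor. Of the two numbers at hand, compound 1 gives the smaller figure, yet compound 2 `Oc1cccc2[nH]c(Cc3ccc(Oc4ccccc4)cc3)nc12`, which gives 5500 nM in this assay, lies within the usual scatter of it, so the two cannot be told apart. Compound 3 `O=S(=O)(Nc1ccc2[nH]c(Cc3ccc(Oc4ccccc4)cc3)nc2c1)c1ccccc1` has not been measured. Its change from compound 1 is (phenylsulfonyl)amino in place of cyano on an aromatic carbon. Going by the values given here, no measured pair shows a change of this kind, so the step of a 1.1-fold lower number from compound 1 to compound 3 (0.05 log units; within the scatter) is only an estimate, with no clear direction beyond the scatter. Compound 3 is expected to give about 3000 nM, within 800 nM to 12000 nM.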

Compound 3, half-maximal inhibitory concentration: 14000 nM
Compound 3: middle estimate off by 4.7-fold (0.67 log units), on the low side; the measured number lies above the stated range.
By their numbers in this assay, from the lowest: compounds 1 and 2 (each within the scatter of the next); then compound 3.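

In this assay, replacing cyano with (phenylsulfonyl)amino on this aromatic carbon gives a 4.1-fold higher number from compound 1 to compound 3 (0.61 log units; beyond the scatter) and so costs some binding. Going by these compounds alone, this is the first step that lies beyond the scatter, showing that the result at this position depends on the group placed there. No measurement at hand explains the loss.

As far as these compounds go, it remains open which part of the new group goes with the weaker binding: the nitrogen, the sulfonyl or the phenyl ring. Where a plain amine or a carboxylic acid on this carbon would fall also remains unknown.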